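A 2-phenylethenyl swap on compound 2

The source may report more compounds than this note shows. Statements on the series, on what has been measured and on what is new or still open speak of the compounds shown alone.

Compound 1 `COc1ccc2c(c1)N(Cc1cn(Cc3ccccc3)nn1)C(=O)CO2` gives > 100000 nM as a limit
Compound 2 `COc1ccc(Cn2cc(CN3C(=O)COc4ccccc43)nn2)cc1` gives 18500 nM

In a functional assay on HT-29 cells (Homo sapiens) for cytotoxicity, read by MTT assay, with a stated time of 6 days (a lower number here means a stronger inhibitor, a higher number a weaker inhibitor), compound 1 reports only a limit (> 100000 nM). Among the compounds with values here, compound 2 holds the only actual number in this set (18500 nM). Compound 3 (`O=C1COc2ccccc2N1Cc1cn(C/C=C/c2ccccc2)nn1`) differs from compound 2 by 2-phenylethenyl in place of 4-methoxyphenyl on a saturated chain carbon bound to an aromatic nitrogen in one place: 2-phenylethenyl in place of 4-methoxyphenyl on a saturated chain carbon bound to an aromatic nitrogen. Within the data shown here, with no measured step to guide the estimate, the expected 1.0-fold lower number from compound 2 to compound 3 (0.01 log units; within the scatter) stays within the scatter, in neither direction. Compound 3 is estimated at 18000 nM with an expected range (6000 nM to 70000 nM).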

Compound 3, half-maximal inhibitory concentration: > 100000 nM
Compound 3: only a limit was reported; the forecaster's own chance of this, stated with the estimate: 25%; at least 5.5-fold (0.74 log units) between middle value and limit.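

In this assay, within the data shown here, the change on a saturated chain carbon bound to an aromatic nitrogen gives the first step that can be read at this position, where 2-phenylethenyl in place of 4-methoxyphenyl gives an at least 5.4-fold higher number from compound 2 to compound 3 (0.73 log units; beyond the scatter). Activity at this position is therefore not kept across these two groups of equal heavy-atom count. The step gives only a minimum size, and the value of compound 3 is a limit: the limit of > 100000 nM in this assay, at which 2 of the 3 values shown sit.

The compounds shown do not separate the loss of the methoxy group from the entry of the double bond. On these data alone, whether an amine or a carboxylic acid in this place would give a number lower than that of compound 2 stays open.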